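A few compounds are considered here, and "the series" means these few. Any claim that something is new, unique, unknown or untested is made for them only; others in the source may bear on it.

Compounds measured in a functional assay on HepG2 cells (Homo sapiens) for antiproliferative activity, read by MTT assay, with a stated time of 72 h (a lower number here means a stronger inhibitor, a higher number a weaker inhibitor), so far:
compound 1 `CC/C=C\C(=O)Nc1cc(Nc2nccc(-c3cn(C)c4ccccc34)n2)c(OC)cc1N(C)CCN(C)C`, 6670 nM;
compound 2 `C=CC(=O)Nc1cc(Nc2nc(C)cc(-c3cn(C)c4ccccc34)n2)c(OC)cc1N(C)CCN(C)C`, 12600 nM;
compound 3 `C=C(Cl)C(=O)Nc1cc(Nc2nc(C)cc(-c3cn(C)c4ccccc34)n2)c(OC)cc1N(C)CCN(C)C`, 3640 nM.

Compound 3 gives the lowest of the three numbers in this assay; compound 1 sits within the scatter of it, compound 2 beyond it. Within the data shown here, the one single-point step measured within the set is a 3.5-fold lower number from compound 2 to compound 3 (0.54 log units; beyond the scatter). Compound 4 `CC/C=C\C(=O)Nc1cc(Nc2nc(C)cc(-c3cn(C)c4ccccc34)n2)c(OC)cc1N(C)CCN(C)C` carries the same change as the path from compound 3 to compound 1, but on the core of compound 3: but-1-en-1-yl in place of 1-chloroethenyl on a carbonyl carbon. Among the measured compounds shown here, no measured step covers this exact exchange; what can be read is that compound 1, which bears but-1-en-1-yl on the other core, gives 6670 nM, and that, with hydrogen in place of the chloro of compound 3, compound 2 gives 12600 nM. Removing the chloro thus lost ground once, and the but-1-en-1-yl analogue measured on the other core landed between compound 2 and compound 3. For compound 4 the expected step is therefore a 2.2-fold higher number from compound 3 to compound 4 (0.34 log units; beyond the scatter), upward and modest. The estimate for compound 4 in this assay is 8000 nM, with a range of 3500 nM to 18000 nM.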

Compound 4, half-maximal inhibitory concentration: 2050 nM
Beside the measured number, compound 4's estimate is 3.9-fold (0.59 log units) above it; the measured number lies below the stated range.
By their numbers in this assay, from the lowest: compounds 4, 3, 1 and 2 (each within the scatter of the next, the first and the last beyond it).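

In this assay, the exchange on the carbonyl carbon reads a 1.8-fold lower number from compound 3 to compound 4 (0.25 log units; within the scatter), so but-1-en-1-yl and 1-chloroethenyl are not separated on this core, whereas vinyl is set apart from but-1-en-1-yl by a 6.1-fold lower number from compound 2 to compound 4 (0.79 log units; beyond the scatter), in the same direction as a 3.5-fold lower number from compound 2 to compound 3 (0.54 log units; beyond the scatter). Among these compounds, with but-1-en-1-yl held fixed, methyl in place of hydrogen on an aromatic carbon gives a 3.3-fold lower number from compound 1 to compound 4 (0.51 log units; beyond the scatter), the first reading of that change on its own in this set. Nothing available gives a reason for these steps.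

Open, from the compounds shown here alone, is whether a longer chain, or an amine at the end of the but-1-en-1-yl chain, would shift the number on the core of compound 4. Also open, going by these compounds, is whether the methyl step holds with vinyl or 1-chloroethenyl on the carbonyl carbon.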